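Lengthening the Amide Chain of Compound 1

A few compounds are considered here, and "the series" means these few. Any claim that something is new, unique, unknown or untested is made for them only; others in the source may bear on it.

Compound 1 `CCC(=O)NCCCO[C@@H]1[C@@H](C)N(C)C[C@H](C)C[C@@](C)(O)[C@H](O[C@@H]2O[C@H](C)C[C@H](N(C)C)[C@H]2O)[C@@H](C)[C@H](O[C@H]2C[C@@](C)(OC)[C@@H](O)[C@H](C)O2)[C@@H](C)C(=O)O[C@H](CC)[C@@]1(C)O` gives 2.74 in a physicochemical assay for lipophilicity, read by HPLC, measured as chromatographic lipophilicity, at pH 7.4; a lower number here means a more polar compound, a higher number a more lipophilic compound. Compound 2 `CC[C@H]1OC(=O)[C@H](C)[C@@H](O[C@H]2C[C@@](C)(OC)[C@@H](O)[C@H](C)O2)[C@H](C)[C@@H](O[C@@H]2O[C@H](C)C[C@H](N(C)C)[C@H]2O)[C@](C)(OC)C[C@@H](C)C(=O)[C@H](C)[C@@H](OCCCNC(C)=O)[C@]1(C)O` gives 2.72 in this assay, a number within the usual scatter of that of compound 1, so the two cannot be told apart on this measure. Compound 3 `CCCCCCCC(=O)NCCCO[C@@H]1[C@@H](C)N(C)C[C@H](C)C[C@@](C)(O)[C@H](O[C@@H]2O[C@H](C)C[C@H](N(C)C)[C@H]2O)[C@@H](C)[C@H](O[C@H]2C[C@@](C)(OC)[C@@H](O)[C@H](C)O2)[C@@H](C)C(=O)O[C@H](CC)[C@@]1(C)O` is not yet measured and differs from compound 1 in one place: pentyl in place of hydrogen on a saturated chain carbon, two bonds along the chain from a carbonyl carbon. Going by the values given here, no measured pair shows what this change does in this assay, so the expectation rests on the change itself; a step upward well beyond the scatter is expected, a number 1.66 log units higher from compound 1 to compound 3 (beyond the scatter). For compound 3 the estimated value in this assay is 4.4, ranging from 3.8 to 5.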

Compound 3, distribution coefficient: 5.18
For compound 3 the middle estimate is 0.78 log units below the measured one, outside the stated range (above it).
By their numbers in this assay, from the lowest: compounds 2 and 1 (each within the scatter of the next); then compound 3.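

Pentyl in place of hydrogen on a saturated chain carbon, two bonds along the chain from a carbonyl carbon, gives a number 2.44 log units higher from compound 1 to compound 3 (beyond the scatter) in this assay and so shows that this position can move the number a long way. The entering group is carbon only, with no ring, no hydrogen-bond donors or acceptors and no net charge. Nothing measured here accounts for the size of this step.

With a single chain length, the compounds shown leave open what butyl would give in place of pentyl. They also leave open whether an amine or a carboxylic acid there would bring the number back toward that of compound 1.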